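The source may hold more compounds than are shown below. What is called first, only, known or untested is meant among the compounds shown, and "the series" means these compounds.

Compound 3 `CCCCCCCCCCCCCCCCCCNC(=O)[C@@H](NC(=O)c1ccccc1)[C@@H](C)O` has no measured number in a functional assay on HepG2 cells (Homo sapiens) for cytotoxicity, read by MTT assay, with a stated time of 48 h; a lower number here means a stronger inhibitor, a higher number a weaker inhibitor: the value recorded for compound 3 is > 400000 nM, which is a limit of the assay rather than a number. The same limit appears in the evidence as the limit of > 400000 nM in this assay, at which 1 of the 3 values shown sits. Compound 1 `CCCCCCCCCCCCCCCCCCNC(=O)[C@@H](N)[C@@H](C)O`, the parent with an unsubstituted amine, gives 44500 nM in this assay. The step of an at least 8.9-fold higher number from compound 1 to compound 3 (0.95 log units; beyond the scatter) thus shows that adding a benzoyl group weakened the compound considerably. Compound 2 `CCCCCCCCCCCCNC(=O)[C@@H](NC(=O)c1cc2ccccc2o1)[C@@H](C)O`, carrying a shorter chain and a benzofuran-based amide, gives 22900 nM in this assay.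

Compound 4 `CCCCCCCCCCCCCCCCCCNC(=O)[C@@H](NC(=O)c1cc2ccccc2o1)[C@@H](C)O` differs from compound 3 by 1-benzofuran-2-yl in place of phenyl on a carbonyl carbon. For the measured compounds named here, no measured step covers exactly this change on the longer chain, but compound 2 shows that a benzofuran amide can sit together with a measurable value. Compound 4 is therefore expected to move in the stronger direction from the limit of compound 3, with the step of an at least 5.0-fold lower number from compound 3 to compound 4 (0.69 log units; beyond the scatter) estimated. The value for compound 4 in this assay is estimated at 80000 nM, with a plausible range from 15000 nM to 400000 nM.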

Compound 4, half-maximal inhibitory concentration: > 200000 nM
Compound 4: a limit, no number; the forecaster's own chance of this, stated with the estimate: 35%; at least 2.5-fold (0.39 log units) between middle value and limit.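

Compound 4 in this assay is a limit and not a number, and compound 3 is a limit too, so the step between them cannot be read: the limit of > 200000 nM in this assay, at which 1 of the 4 values shown sits.

What can be read comes from the other two comparisons. With the (1-benzofuran-2-yl)carbonyl amide held fixed, hexyl in place of hydrogen on the chain gives an at least 8.7-fold higher number from compound 2 to compound 4 (0.94 log units; beyond the scatter), so the measurable value of compound 2 does not carry over to the longer chain. On the long chain, putting (1-benzofuran-2-yl)carbonyl on the amine nitrogen gives an at least 4.4-fold higher number from compound 1 to compound 4 (0.65 log units; beyond the scatter), the same direction as the benzoyl step, an at least 8.9-fold higher number from compound 1 to compound 3 (0.95 log units; beyond the scatter).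

From the compounds shown here alone, whether benzoyl or (1-benzofuran-2-yl)carbonyl is the better group on the carbonyl carbon stays open, since neither has a number on the long chain. Also open, going by these compounds, is how a benzoyl amide on the shorter chain, or an amine or carboxylic acid on the aromatic ring, would read.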